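Nitro for cyano on a second pentafluorosulfanyl-bearing core

This account rests on a few compounds, and the source may have more. Where it says the series, first, only, none or still open, it means among the compounds named here.

Compound 1 `CC(O)(CSc1cccc(S(F)(F)(F)(F)F)c1)C(=O)Nc1ccc(C#N)c(C(F)(F)F)c1` and compound 2 `CC(O)(CSc1cccc(S(F)(F)(F)(F)F)c1)C(=O)Nc1ccc([N+](=O)[O-])c(C(F)(F)F)c1` share one core; compound 3 `CC(O)(CS(=O)(=O)c1ccc(S(F)(F)(F)(F)F)cc1)C(=O)Nc1ccc(C#N)cc1C(F)(F)F` and compound 4 `CC(O)(CS(=O)(=O)c1ccc(S(F)(F)(F)(F)F)cc1)C(=O)Nc1ccc([N+](=O)[O-])cc1C(F)(F)F` share another, and the difference between the two cores is not broken down here. In a functional assay on VCaP cells (Homo sapiens) for antiproliferative activity, read by propidium iodide staining, with a stated time of 96 h (on this read-out higher numbers stand for weaker inhibition and lower numbers for stronger inhibition), compound 1 gives 31700 nM, while compound 2 gives 9800 nM. Compound 3 gives 43000 nM in this assay, the highest number of the three measured compounds, within the scatter of compound 1 and beyond it from compound 2. The change from compound 1 to compound 2 is nitro in place of cyano on an aromatic carbon, and it made a step of a 3.2-fold lower number from compound 1 to compound 2 (0.51 log units; beyond the scatter). The change from compound 3 to compound 4 is nitro in place of cyano on an aromatic carbon; it is the same kind of change, not the same, since in compound 2 the nitro stands ortho to a trifluoromethyl group and in compound 4 it stands meta to a trifluoromethyl group. Going by the values given here, only one such step has been measured, so the expectation rests on it alone. Among the compounds with values here, the step from compound 3 to compound 4 in this assay is expected to be a 3.1-fold lower number from compound 3 to compound 4 (0.49 log units; beyond the scatter), because the single measured step, a 3.2-fold lower number from compound 1 to compound 2 (0.51 log units; beyond the scatter), was modest. Compound 4 is therefore estimated at 14000 nM, between 5000 nM and 40000 nM.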

Compound 4, half-maximal inhibitory concentration: 28600 nM
Beside the measured number, compound 4's estimate is 2.0-fold (0.31 log units) below it, within the range that was stated.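

In this assay, nitro in place of cyano on an aromatic carbon gave a 1.5-fold lower number from compound 3 to compound 4 (0.18 log units; within the scatter), so on this second core the step cannot be told apart from repeat scatter. Set beside the earlier step, the new one does not differ from it by more than the scatter of two such steps allows: the same change on two cores in this assay, a 3.2-fold lower number (0.51 log units; beyond the scatter) from compound 1 to compound 2 and a 1.5-fold lower number (0.18 log units; within the scatter) from compound 3 to compound 4, 2.2-fold (0.33 log units) apart, within the scatter of two such steps. Going by these compounds alone, this means the result fits a similar step on both cores, but it does not show that the step carries over, as only two cores are compared, only one of the two steps lies beyond the scatter, and in compound 4 the nitro stands meta to a trifluoromethyl group, a placing that compound 2 does not share.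

The compounds shown leave open whether an amine or a carboxylic acid on that aromatic carbon would give a step beyond the scatter on either core. They also leave open which part of the difference between the two cores bears on the size of the step.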